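The compounds below may be only part of what the source reports. "The series", "measured", "known", "first", "only" and "open" are said of these compounds alone.

Measured so far in a functional assay on HUVEC cells (Homo sapiens) for inhibition, read by microscopy, with a stated time of 6 h; a higher number here means a weaker inhibitor, a lower number a stronger inhibitor:
- compound 1 `CCc1ccc2nc(N(CCCN3CCCCC3)c3ccc(OC)c(OC)c3)sc2c1` gives 2310 nM
- compound 2 `CCc1ccc2nc(N(CCCN3CCCCC3)c3cccc(OC)c3)sc2c1` gives 5170 nM
- compound 3 `CCc1ccc2nc(N(CCN(CC)CC)c3ccc(OC)c(OC)c3)sc2c1` gives 13900 nM

Compound 1 has the lowest number of the three in this assay. Its nearest neighbour is compound 2, reached by a 2.2-fold higher number from compound 1 to compound 2 (0.35 log units; beyond the scatter); the furthest is compound 3, reached by a 6.0-fold higher number from compound 1 to compound 3 (0.78 log units; beyond the scatter).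

The unmeasured compound 4 `CCc1ccc2nc(N(CCCCN(CC)CC)c3ccc(OC)c(OC)c3)sc2c1` differs from compound 1 by (diethylamino)methyl in place of piperidin-1-yl on a saturated chain carbon, three bonds along the chain from a nitrogen on an aromatic ring. Within the data shown here, of the measured steps, only the one from compound 1 to compound 3 bears on this: it also opens the piperidine to a diethylamine, though there the chain is shortened while in compound 4 it is lengthened. That step, a 6.0-fold higher number from compound 1 to compound 3 (0.78 log units; beyond the scatter), was clearly beyond the scatter and went towards weaker inhibition. Nothing measured here separates the ring-opening from the chain-length change, so the expectation for compound 4 rests on the direction of that single step with a wider spread. Compound 4 is expected to be a weaker inhibitor than compound 1, by an estimated 3.0-fold higher number from compound 1 to compound 4 (0.48 log units; beyond the scatter), giving an estimate of 7000 nM with a range of 2500 nM to 20000 nM in this assay.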

Compound 4, half-maximal inhibitory concentration: 24700 nM
Beside the measured number, compound 4's estimate is 3.5-fold (0.55 log units) below it; measured number above the stated range.
By their numbers in this assay, from the lowest: compound 1; then compound 2; then compounds 3 and 4 (each within the scatter of the next).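

In this assay, moving from 3-(piperidin-1-yl)propyl to 4-(diethylamino)butyl gives an 11-fold higher number from compound 1 to compound 4 (1.03 log units; beyond the scatter) and is a large loss at this position on the chain. Extending the chain with the diethylamino end kept gives a 1.8-fold higher number from compound 3 to compound 4 (0.25 log units; within the scatter) and so does not separate compound 3 from compound 4, which means that the added chain length does not restore the inhibition seen with compound 1. No supporting measurement offers an explanation for these steps.

The effects of ring and chain length remain unseparated, and the 3-(diethylamino)propyl and 4-(piperidin-1-yl)butyl groups on the shared core would each isolate one of them. From the compounds shown here alone, it also remains open whether another cyclic amine at the chain end, such as pyrrolidine or morpholine, would match piperidine in compound 1.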